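Swapping dichlorophenyl for dimethoxyphenyl on a chalcone-like ketone

The source may report more compounds than this note shows. Statements on the series, on what has been measured and on what is new or still open speak of the compounds shown alone.

Compound 1 `COc1cc(-c2cc(/C=C/C(=O)c3ccc(Cl)c(Cl)c3)[nH]n2)cc(OC)c1OC` is examined in a functional assay on A549 cells (Homo sapiens) for inhibition, read by sulforhodamine B assay, with a stated time of 48 h; on this read-out higher numbers stand for weaker inhibition of growth and lower numbers for stronger inhibition of growth. In this assay compound 1 reaches only the assay limit, giving > 100000 nM, which is a limit and not a measured number. Compound 2 `COc1ccc(-c2cc(/C=C/C(=O)c3ccc(N)cc3)[nH]n2)cc1OC`, which carries a different pair of aryl groups on the shared core, gives 10100 nM in this assay. Among the measured compounds shown here, the only firm point about compound 1 is thus (the limit of > 100000 nM in this assay, at which 1 of the 2 values shown sits), so it stands at the weak end of what has been recorded.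

Compound 3 `COc1ccc(C(=O)/C=C/c2cc(-c3cc(OC)c(OC)c(OC)c3)n[nH]2)cc1OC` is not yet measured. It differs from compound 1 in one place: 3,4-dimethoxyphenyl in place of 3,4-dichlorophenyl on a carbonyl carbon. Since compound 1 sits at the limit, its step to compound 3 cannot be measured directly. Compound 2 shows that a compound of this core with a 3,4-dimethoxyphenyl group can give a measurable number in this assay, so compound 3 is expected to improve on compound 1 by about an at least 3.3-fold lower number from compound 1 to compound 3 (0.52 log units; beyond the scatter), a step expected beyond the scatter. Compound 3 is therefore estimated at 30000 nM in this assay, within a range from 8000 nM to 100000 nM.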

Compound 3, concentration for total growth inhibition: 4590 nM
The estimate for compound 3 lay 6.5-fold (0.82 log units) above the measured number; the whole stated range lies above it.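

In this assay, 3,4-dimethoxyphenyl in place of 3,4-dichlorophenyl on a carbonyl carbon gives an at least 21-fold lower number from compound 1 to compound 3 (1.33 log units; beyond the scatter), which shows that the group at this position can decide whether the shared core gives a measurable number at all. Compound 1 gives a limit and not a number, so this step has a floor and no upper end: the limit of > 100000 nM in this assay, at which 1 of the 3 values shown sits. Compound 1 and compound 2 differ in more than one place and could not show this, whereas here the rest of the molecule stays the same and the change is tied to this one position.

The compounds shown do not tell whether an unsubstituted phenyl, or a phenyl bearing a hydroxyl or a fluorine, would behave like 3,4-dimethoxyphenyl or like 3,4-dichlorophenyl at this position. They also leave open whether the step holds on other cell lines.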